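Nitro substitution and aqueous solubility in two quinolone series

The source may hold more compounds than are shown below. What is called first, only, known or untested is meant among the compounds shown, and "the series" means these compounds.

Compound 1 `CCCCCOCc1cc(=O)c2ccccc2[nH]1`: > 200000 nM
Compound 2 `CCCCCOCc1cc(=O)c2cc([N+](=O)[O-])ccc2[nH]1`: 15000 nM
Compound 3 `CCCCCCCc1[nH]c2ccccc2c(=O)c1C(=O)O`: 15000 nM

Three compounds have been examined in a physicochemical assay for solubility, read by HPLC, at pH 7.4; on this read-out higher numbers stand for higher solubility and lower numbers for lower solubility. The reading for compound 1 is a limit of this assay rather than a number, since it sits at the limit of > 200000 nM in this assay, at which 1 of the 3 values shown sits. In this assay compound 2 gives 15000 nM. The two compounds differ in one place, (nitro in place of hydrogen on an aromatic carbon), and that change produced an at least 13-fold lower number from compound 1 to compound 2 (1.12 log units; beyond the scatter).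

Compound 3 belongs to a second core; the difference between the core of compound 3 and the core of compound 1 is not broken down here. In this assay compound 3 gives 15000 nM, a figure that lies level with compound 2 within the usual scatter, so no order between the two can be drawn.

Compound 4 `CCCCCCCc1[nH]c2ccc([N+](=O)[O-])cc2c(=O)c1C(=O)O` has not yet been measured. Within the data shown here, it differs from compound 3 in one place, (nitro in place of hydrogen on an aromatic carbon), which is the same change as the one from compound 1 to compound 2, placed in the same way on the ring. Resting on the step of an at least 13-fold lower number from compound 1 to compound 2 (1.12 log units; beyond the scatter), and on the starting value of compound 3, the number for compound 4 is expected to fall by a 13-fold lower number from compound 3 to compound 4 (1.10 log units; beyond the scatter). The estimate for compound 4 in this assay is therefore 1200 nM, with an expected range from 200 nM to 6000 nM.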

Compound 4, solubility: 15000 nM
The estimate for compound 4 lay 13-fold (1.10 log units) below the measured number, outside the stated range (above it).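

In this assay, nitro in place of hydrogen on an aromatic carbon gives no change at the digits printed from compound 3 to compound 4 (within the scatter), whereas the same change on the other core gave an at least 13-fold lower number from compound 1 to compound 2 (1.12 log units; beyond the scatter), so the large step seen in the first pair did not carry over to the second. The first of these steps has an open end, since the reading for compound 1 is a limit of the assay and not a number: the limit of > 200000 nM in this assay, at which 1 of the 4 values shown sits. What the two pairs do not show is which feature of the cores separates the outcomes, as the core of compound 1 and the core of compound 3 differ in more than one place, and a single pair on each core says nothing about how the change would behave on a third core or at another ring position.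

The compounds shown leave open whether the step would return if the carboxylic acid were removed from the core of compound 3, or would vanish if a carboxylic acid were added to the core of compound 1. They also leave open whether an amine or a fluorine atom in place of the nitro on the same aromatic carbon would follow either pair.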